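From thiophen-3-yl to furan-2-yl on a shared core

The source may hold more compounds than are shown below. What is called first, only, known or untested is meant among the compounds shown, and "the series" means these compounds.

Compound 1 `COc1cc(C(=O)c2cn(-c3ccc(C)cc3)cc2-c2ccco2)cc(OC)c1OC` gives 22 nM
Compound 2 `COc1cc(C(=O)c2cn(-c3ccc(F)cc3)cc2-c2ccsc2)cc(OC)c1OC` gives 15 nM

In a functional assay on MCF7 cells (Homo sapiens) for inhibition, with a stated time of 96 h (on this read-out lower numbers stand for stronger inhibition and higher numbers for weaker inhibition), compound 2 stands at 15 nM and compound 1 at 22 nM on the same scale, so these two values lie within the usual scatter of each other. Compound 3 `COc1cc(C(=O)c2cn(-c3ccc(F)cc3)cc2-c2ccco2)cc(OC)c1OC` has not been measured yet. It differs from compound 2 by one change, furan-2-yl in place of thiophen-3-yl on an aromatic carbon, and it keeps the 4-fluorophenyl group. Compound 1 also carries furan-2-yl and gives 22 nM with another group where compound 3 has the 4-fluorophenyl group. Among the compounds with values here, no measured pair shows this change alone. In this assay no step beyond the scatter is expected in either direction, and the estimated change is a 1.3-fold higher number from compound 2 to compound 3 (0.12 log units; within the scatter) for now. For compound 3 the estimated value is 20 nM with an expected range from 8 nM to 50 nM in this assay.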

Compound 3, half-maximal inhibitory concentration: 17 nM
Compound 3: middle estimate off by 1.2-fold (0.07 log units), on the high side; low and high end bracket the measured number.
By their numbers in this assay, from the lowest: compounds 2, 3 and 1 (each within the scatter of the next).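

With the 4-fluorophenyl group kept, this pair isolates furan-2-yl in place of thiophen-3-yl on the shared core, and in this assay the swap gives a 1.1-fold higher number from compound 2 to compound 3 (0.05 log units; within the scatter), so on this read-out the sulfur and oxygen rings cannot be told apart at this position. The same compound also isolates a second change, fluoro in place of methyl with furan-2-yl kept, and that step, a 1.3-fold lower number from compound 1 to compound 3 (0.11 log units; within the scatter), cannot be told from scatter either. Nothing available here speaks to what lies behind these two results.

On these data alone, all three compounds carry a five-membered aromatic ring at this position, so it remains open whether an amine, a carboxylic acid or a longer chain there would stay in the same range. As far as these compounds go, it is equally open whether a methoxy group or a chlorine atom in place of the fluoro would do so.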